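A few compounds are considered here, and "the series" means these few. Any claim that something is new, unique, unknown or untested is made for them only; others in the source may bear on it.

Measured so far:
Compound 1, `COc1ccc(-c2c(C#N)c(N)nc(SCc3csc(-c4ccc(Cl)cn4)n3)c2C#N)cc1`, gives 24 nM in an assay on CHO cells for displacement of a labelled ligand from adenosine receptor A1 (Homo sapiens); a higher number here means a weaker inhibitor, a lower number a stronger inhibitor.
Compound 2, `COc1ccc(-c2c(C#N)c(N)nc(SCc3cscn3)c2C#N)cc1`, gives 1.3 nM in this assay.
Compound 3, `COc1ccc(-c2c(C#N)c(N)nc(SCc3csc(-c4ccc(Cl)cc4)n3)c2C#N)cc1`, gives 5 nM in this assay.

Compound 3 holds the second highest of these three numbers; its position is fixed by a 4.8-fold lower number from compound 1 to compound 3 (0.68 log units; beyond the scatter) and by a 3.8-fold higher number from compound 2 to compound 3 (0.59 log units; beyond the scatter).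

Compound 4, `COc1ccc(-c2c(C#N)c(N)nc(SCc3csc(-c4ccc(F)cc4)n3)c2C#N)cc1`, differs from compound 3 in one place: fluoro in place of chloro on an aromatic carbon. Among the compounds with values here, no measured step swaps one halogen for another. Within the data shown here, the steps of a 3.8-fold higher number from compound 2 to compound 3 (0.59 log units; beyond the scatter) and a 4.8-fold lower number from compound 1 to compound 3 (0.68 log units; beyond the scatter) exchange the whole group on that carbon, so they show only that this group shifts the number modestly. For a change of one halogen I therefore expect no step beyond the scatter, a 1.1-fold lower number from compound 3 to compound 4 (0.05 log units; within the scatter). Compound 4 is expected to give 4.5 nM, with a range from 1.5 nM to 13 nM.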

Compound 4, inhibition constant: 2.3 nM
Compound 4: the middle estimate sits 2.0-fold (0.29 log units) above what was measured; measured number inside the range.
By their numbers in this assay, from the lowest: compounds 2 and 4 (each within the scatter of the next); then compound 3; then compound 1.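

Swapping one halogen on the outer six-membered ring is enough to shift the result: in this assay, fluoro in place of chloro gives a 2.2-fold lower number from compound 3 to compound 4 (0.34 log units; beyond the scatter), so the effect of this group depends on the halogen it carries. With fluoro, the added ring cannot be told apart from plain hydrogen, with a 1.8-fold higher number from compound 2 to compound 4 (0.25 log units; within the scatter), and 4-fluorophenyl in place of 5-chloropyridin-2-yl gives a 10-fold lower number from compound 1 to compound 4 (1.02 log units; beyond the scatter). Nothing shown here explains these shifts. Still open, from the compounds shown here alone, is how a methoxy group or an amine on that same carbon would compare, and where an unsubstituted phenyl would fall.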